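Removing one methyl from the sec-butyl end of compound 2

This account rests on a few compounds, and the source may have more. Where it says the series, first, only, none or still open, it means among the compounds named here.

Measured so far in a functional assay on WiDr cells (Homo sapiens) for antiproliferative activity, read by sulforhodamine B assay, with a stated time of 48 h; a lower number here means a stronger inhibitor of growth, a higher number a weaker inhibitor of growth
- compound 1 `CCCCCCCCCCCCCCC[C@@H](O)[C@@H](N)C(C)C` gives 20000 nM
- compound 2 `CCCCCCCCC[C@@H](O)[C@@H](N)[C@@H](C)CC` gives 2300 nM

Of these two numbers, compound 2 has the lower, so it is the stronger inhibitor of growth, and the gap to compound 1 lies beyond the usual scatter. The next compound, compound 3 `CCCCCCCCC[C@@H](O)[C@@H](N)C(C)C`, differs from compound 2 as follows: hydrogen in place of methyl on a saturated chain carbon, three bonds along the chain from an amine nitrogen. The same difference reads sec-butyl to isopropyl. Within the data shown here, no measured pair shows this change alone. Compound 1 also carries isopropyl and gives 20000 nM in this assay but differs from compound 2 elsewhere as well, so it offers only weak guidance. A small rise in the number is expected for the loss of a single methyl, probably not beyond the scatter. The estimated change is a 1.3-fold higher number from compound 2 to compound 3 (0.12 log units; within the scatter) on this reading. Compound 3 is expected near 3000 nM in this assay with an estimated range from 1200 nM to 8000 nM for the measurement.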

Compound 3, concentration for 50% growth inhibition: 11000 nM
The estimate for compound 3 lay 3.7-fold (0.56 log units) below the measured number, outside the stated range (above it).
By their numbers in this assay, from the lowest: compound 2; then compounds 3 and 1 (each within the scatter of the next).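

In this assay, among these compounds, the sec-butyl to isopropyl change gives the first reading of a single place: a 4.8-fold higher number from compound 2 to compound 3 (0.68 log units; beyond the scatter), so one methyl on a saturated chain carbon, three bonds along the chain from an amine nitrogen, makes a difference beyond the scatter at this end of the molecule. With the isopropyl end held constant, the chain change gives a 1.8-fold lower number from compound 1 to compound 3 (0.26 log units; within the scatter), which lies within the scatter, so this pair shows no readable effect of the extra hexyl portion of the chain. No measured evidence on the origin of the methyl step is available here.

The compounds shown leave open whether a longer chain would also make no readable difference when paired with the sec-butyl end, as the hexyl comparison rests on the isopropyl end alone. They also leave open how far this end tolerates other groups, such as tert-butyl, cyclohexyl or phenyl, and whether the methyl step depends on the configuration at the carbon that bears it.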